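Swapping indole for fluorophenyl on a cytotoxicity limit

The source may report more compounds than this note shows. Statements on the series, on what has been measured and on what is new or still open speak of the compounds shown alone.

Measured in an ADME assay on HEK293 cells (Homo sapiens) for cytotoxicity, read by CellTiter-Glo and resazurin assay, with a stated time of 72 h (on this read-out higher numbers stand for an effect only at larger amounts of compound and lower numbers for an effect already at smaller amounts), each value a limit:
- Compound 1 `CC(C)N(Cc1cccc(OCCCCCC(=O)O)c1)C(=O)c1ccc(-c2cccc(Oc3ccccc3)c2)cc1` gives > 18700 nM
- Compound 2 `CC(C)N(Cc1cccc(OCCCCCC(=O)O)c1)C(=O)c1ccc(-c2ccsc2)cc1` gives > 26000 nM
- Compound 3 `CC(C)N(Cc1cccc(OCCCCCC(=O)O)c1)C(=O)c1ccc(-c2ccc3cc[nH]c3c2)cc1` gives > 26000 nM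

Compound 3 has no exact value, only the limit > 26000 nM. The other two compounds also give only limits, so compound 3 cannot be ranked against them.

Compound 4 `CC(C)N(Cc1cccc(OCCCCCC(=O)O)c1)C(=O)c1ccc(-c2cccc(F)c2)cc1` has 3-fluorophenyl in place of 1H-indol-6-yl on an aromatic carbon.

One measured step changes the group at this same place, a step that the two limits leave unreadable from compound 2 to compound 3, and it gives no size to build on. Compound 1 carries yet another group there and also gives only a limit, > 18700 nM. With different groups at this place, all three compounds stay at limits, so no step beyond the usual scatter is expected, and no direction can be named.

The expected change is a step that the limit leaves unreadable from compound 3 to compound 4. For compound 4 the estimated value is 30000 nM, with an expected range from 18000 nM to 60000 nM, and most likely only a limit will be reported.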

Compound 4, half-maximal effective concentration: > 26000 nM
Compound 4: a limit, no number; the forecaster's own chance of this, stated with the estimate: 85%; the middle value does not contradict the limit.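

For the compounds shown here, compound 1, compound 2 and compound 3 give only limits in this assay, and so does compound 4, so no step to compound 4 can be read. Going by these compounds, what stays open is at what concentration, if any, these four compounds show an effect in this assay.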